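The source may report more compounds than this note shows. Statements on the series, on what has been measured and on what is new or still open speak of the compounds shown alone.

Among the compounds with values here, in an ADME assay on L02 cells (Homo sapiens) for cytotoxicity, read by MTT assay, with a stated time of 72 h (on this read-out lower numbers stand for stronger inhibition and higher numbers for weaker inhibition), compound 1 `Cc1ccccc1NC(=O)CCC(=O)OCCCCCCSc1ccc([N+](=O)[O-])c2nonc12` gives 9490 nM and compound 2 `O=C(CCC(=O)OCCCCCCSc1ccc([N+](=O)[O-])c2nonc12)Nc1cccc(Cl)c1` gives 6930 nM, which places compound 2 within the scatter of the only other measured compound. Compound 3 `O=C(CCC(=O)OCCCCCCSc1ccc([N+](=O)[O-])c2nonc12)Nc1ccc(C(F)(F)F)cc1` carries 4-(trifluoromethyl)phenyl in place of 3-chlorophenyl on an amide-type nitrogen. Within the data shown here, the one measured step that bears on this change, a 1.4-fold lower number from compound 1 to compound 2 (0.14 log units; within the scatter), replaced the group at that same nitrogen, so no shift beyond the scatter is expected in this assay. The expected step is a 1.1-fold lower number from compound 2 to compound 3 (0.03 log units; within the scatter). For compound 3 the estimated value is 6500 nM, with an expected range of 3200 nM to 13000 nM.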

Compound 3, half-maximal inhibitory concentration: 5010 nM
The estimate for compound 3 lay 1.3-fold (0.11 log units) above the measured number, within the range that was stated.
By their numbers in this assay, from the lowest: compounds 3, 2 and 1 (each within the scatter of the next).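

With 4-(trifluoromethyl)phenyl on the amide-type nitrogen, this assay shows a 1.4-fold lower number from compound 2 to compound 3 (0.14 log units; within the scatter) and a 1.9-fold lower number from compound 1 to compound 3 (0.28 log units; within the scatter). The three substituted phenyl groups at this nitrogen therefore give numbers that cannot be told apart, even with 10 heavy atoms entering where 7 leave. Nothing available offers an account of this result. As far as these compounds go, whether an amine or a carboxylic acid in place of these phenyl groups would shift the number beyond the scatter remains open.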